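Dichlorophenyl thioether in place of methoxyphenyl thioether

This account rests on a few compounds, and the source may have more. Where it says the series, first, only, none or still open, it means among the compounds named here.

These compounds share one core that carries two amino groups and a phenyl ring, with a further aryl group attached through oxygen or sulfur. In a functional assay on SF-539 cells (Homo sapiens) for inhibition, read by sulforhodamine B assay, with a stated time of 48 h (a higher number here means that more compound is tolerated, a lower number that less compound is tolerated), compound 1 `Nc1cc(N)c2nc(-c3ccccc3)c(Oc3ccc(Cl)c(Cl)c3)nc2c1` gives 64600 nM. Compound 2 `COc1ccc(Sc2nc3cc(N)cc(N)c3nc2-c2ccccc2)cc1` gives only a limit in this assay, < 100000 nM, which is what the limit of < 100000 nM in this assay, at which 1 of the 2 values shown sits, marks. The step that the limit leaves unreadable from compound 1 to compound 2 is therefore not readable in size. Compound 3 `Nc1cc(N)c2nc(-c3ccccc3)c(Sc3ccc(Cl)c(Cl)c3)nc2c1` has not yet been measured; it differs from compound 2 by 3,4-dichlorophenyl in place of 4-methoxyphenyl on a sulfur, that is, (4-methoxyphenyl)sulfanyl to (3,4-dichlorophenyl)sulfanyl. Compound 3 thus carries the same 3,4-dichlorophenyl group as compound 1, joined through sulfur instead of oxygen. Among the measured compounds shown here, no measured step bears directly on this change, so the expectation rests on compound 1 and its value 64600 nM. Compound 3 is expected to come in near 60000 nM, within 20000 nM to 100000 nM. This corresponds to an expected step that the limit leaves unreadable from compound 2 to compound 3, which cannot be checked against a limit.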

Compound 3, concentration lethal to 50% of the cells: < 100000 nM
Compound 3 ended at the assay's limit; the forecaster's own chance of this, stated with the estimate: 30%; the middle value is on the limit's open side.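

No step can be read among compound 1, compound 2 and compound 3, because the comparison stops at a limit: the limit of < 100000 nM in this assay, at which 2 of the 3 values shown sit.

Still open, as far as these compounds go, is whether joining the 3,4-dichlorophenyl group through sulfur rather than oxygen matters, and how the 3,4-dichlorophenyl and 4-methoxyphenyl groups compare on sulfur.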